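The source may hold more compounds than are shown below. What is called first, only, known or untested is meant among the compounds shown, and "the series" means these compounds.

Compound 1 `ClCc1ccccc1Cn1cnc2c(Cl)nc(Cl)nc21` and compound 2 `ClCc1cccc(Cn2cnc3c(Cl)nc(Cl)nc32)c1` hold the same atoms joined differently; the difference between the two cores is not broken down here. In a functional assay on OVCAR-4 cells (Homo sapiens) for cytotoxicity, read by sulforhodamine B assay, with a stated time of 48 h (a lower number here means a stronger inhibitor of growth, a higher number a weaker inhibitor of growth), compound 1 gives 3630 nM, and compound 2 gives 20000 nM, the highest of the three measured numbers and beyond the scatter from both of the others. Compound 3 `Nc1nc(Cl)c2ncn(Cc3ccccc3CCl)c2n1` follows from compound 1 by amino in place of chloro on an aromatic carbon; in this assay compound 3 gives 6460 nM, a step of a 1.8-fold higher number from compound 1 to compound 3 (0.25 log units; within the scatter). Compound 4 `Nc1nc(Cl)c2ncn(Cc3cccc(CCl)c3)c2n1` is not yet measured. It follows from compound 2 by amino in place of chloro on an aromatic carbon, the same change as from compound 1 to compound 3, with the place described in the same words; among the compounds here this change occurs twice. The expectation for compound 4 rests on that single measured step, and a step of a 1.5-fold higher number from compound 2 to compound 4 (0.18 log units; within the scatter) is expected in this assay because a 1.8-fold higher number from compound 1 to compound 3 (0.25 log units; within the scatter) stayed within the scatter. Compound 4 is therefore estimated at 30000 nM in this assay, with a range from 12000 nM to 80000 nM expected.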

Compound 4, concentration for total growth inhibition: 4260 nM
Compound 4: the middle estimate sits 7.0-fold (0.85 log units) above what was measured; the measured number lies below the stated range.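

In this assay, amino in place of chloro on an aromatic carbon gives a 4.7-fold lower number from compound 2 to compound 4 (0.67 log units; beyond the scatter), and the change does not carry over at a constant size from one core to the other: the same change on two cores in this assay, a 1.8-fold higher number (0.25 log units; within the scatter) from compound 1 to compound 3 and a 4.7-fold lower number (0.67 log units; beyond the scatter) from compound 2 to compound 4, 8.4-fold (0.92 log units) apart, beyond the scatter of two such steps

On the core of compound 2 the step lies beyond the scatter, while on the core of compound 1 it stays within the scatter, so in this series a step read on one of these cores is a poor guide to the same change on the other. Among these compounds, this does not show why the two cores differ or how the change would behave on a further core, as it rests on only two pairs and the data give no cause.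

The compounds shown carry only chloro or amino at this place, so the outcome with a methylamino or methoxy group there remains open. Every compound also keeps the chloromethyl group, leaving open what a hydroxymethyl group or a longer chain in its place would do to these numbers.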